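The source may report more compounds than this note shows. Statements on the series, on what has been measured and on what is new or still open speak of the compounds shown alone.

Measured so far in a functional assay on BJAB cells (Homo sapiens) for antiproliferative activity, with a stated time of 4 days; on this read-out higher numbers stand for an effect only at larger amounts of compound and lower numbers for an effect already at smaller amounts:
compound 1, `COC(=O)c1c(Cc2ccccc2[N+](=O)[O-])c(C)nn1-c1nc(-c2ccc(Cl)c(Cl)c2)cs1`: 377000 nM
compound 2, `Cc1ccc(-c2c(C)nn(-c3nc(-c4ccc(Cl)c(Cl)c4)c(SC(C)C)s3)c2C(=O)O)cc1`: 3800 nM
compound 3, `Cc1c(-c2cc(Cl)cc(Cl)c2)c(C(=O)O)nn1-c1nc(-c2cc(Cl)ccc2F)c(SC(C)C)s1`: 4800 nM

Compound 2 and compound 3 sit close together in this assay; the gap between them lies within the scatter, so no order between the two can be read. Compound 1 stands far beyond the scatter from compound 2, at a much higher number. For the measured compounds named here, no pair of measured compounds differs in a single place, so no measured step is available to anchor the next change.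

Compound 4, `Cc1nn(-c2nc(-c3ccc(Cl)c(Cl)c3)c(SC(C)C)s2)c(C(=O)O)c1-c1ccc(Cl)cc1`, is to be measured in this assay. It differs from compound 2 in one place: chloro in place of methyl on an aromatic carbon. With no measured step of this kind in hand, the expectation is a small step, a 1.1-fold lower number from compound 2 to compound 4 (0.04 log units; within the scatter), not beyond the scatter in either direction. Compound 4 is therefore estimated at 3500 nM, with a range from 1500 nM to 8000 nM.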

Compound 4, half-maximal effective concentration: 2500 nM
Compound 4: middle estimate off by 1.4-fold (0.15 log units), on the high side; measured number inside the range.
By their numbers in this assay, from the lowest: compounds 4, 2 and 3 (each within the scatter of the next); then compound 1.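

In this assay, for the compounds shown here, the change from 4-methylphenyl to 4-chlorophenyl reads as a 1.5-fold lower number from compound 2 to compound 4 (0.18 log units; within the scatter) and gives the only measured step at this position. On this aromatic carbon, methyl and chloro therefore cannot be told apart. No evidence on the cause of this step is at hand.

From the compounds shown here alone, how an amine, a methoxy group or a trifluoromethyl group on this carbon would read remains open. Also open, going by these compounds, is whether chloro in place of methyl gives a similar step elsewhere.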